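The compounds below may be only part of what the source reports. "The series", "measured", "known", "first", "only" and "open" are said of these compounds alone.

Compound 1 `CCn1nc(C)c2c1CCN(C(C(=O)NC)c1ccccc1)C2CCc1ccc(Cl)cc1`: 12 nM
Compound 2 `CCn1nc(C)c2c1CCN(C(C(=O)NC)c1ccccc1)C2CCc1ccccc1F`: 22 nM
Compound 3 `CCn1nc(C)c2c1CCN([C@@H](C(=O)NC)c1ccccc1)[C@H]2CCc1ccc(C(F)(F)F)cc1`: 3 nM

In a functional assay on CHO cells for antagonist activity at Orexin receptor type 2 (Homo sapiens), read by FLIPR and calcium flux (a lower number here means a stronger inhibitor, a higher number a weaker inhibitor), compound 2 gives 22 nM, the highest number of the three. Compound 1 is nearest, and the step of a 1.8-fold higher number from compound 1 to compound 2 (0.26 log units; within the scatter) stays within the scatter. Compound 3 is furthest and gives 3 nM, a gap beyond the scatter.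

Compound 4 `CCn1nc(C)c2c1CCN(C(C(=O)NC)c1ccccc1)C2CCc1ccc(C)cc1` has not been measured. It carries 4-methylphenyl in place of 2-fluorophenyl on a saturated chain carbon, two bonds along the chain from a saturated ring carbon. Among the measured compounds shown here, only one measured step concerns the same place: a 1.8-fold higher number from compound 1 to compound 2 (0.26 log units; within the scatter), which was within the scatter, and compound 1 with its 4-chlorophenyl gave 12 nM. From this a small step in the assay is expected, a 2.2-fold lower number from compound 2 to compound 4 (0.34 log units; beyond the scatter), toward the number of compound 1 rather than beyond it. Compound 4 is therefore estimated at 10 nM, within a range from 3 nM to 30 nM.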

Compound 4, half-maximal inhibitory concentration: 6 nM
Compound 4: middle estimate off by 1.7-fold (0.22 log units), on the high side; the measured number falls inside the stated range.
By their numbers in this assay, from the lowest: compounds 3, 4, 1 and 2 (each within the scatter of the next, the first and the last beyond it).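

In this assay, this position now shows a step beyond the scatter: 4-methylphenyl in place of 2-fluorophenyl gives a 3.7-fold lower number from compound 2 to compound 4 (0.56 log units; beyond the scatter) and so changes both the group and where it sits on the ring. Methyl in place of chloro gives a 2.0-fold lower number from compound 1 to compound 4 (0.30 log units; within the scatter) and stays within the scatter, so these two groups cannot be told apart here. No measurement available explains either step. The compounds shown leave open which of the two changes matters, since neither 4-fluorophenyl nor 2-methylphenyl is among them.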